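The source may report more compounds than this note shows. Statements on the series, on what has been measured and on what is new or still open speak of the compounds shown alone.

compound 1 `COC(=O)c1cc(=O)c2cc(NC(=O)Nc3ccc(Cl)c(C(F)(F)F)c3)ccc2[nH]1` — > 6350 nM
compound 2 `COC(=O)c1cc(=O)c2cc(NC(=O)Nc3ccc(Cl)c(Cl)c3)ccc2[nH]1` — > 6350 nM

In a functional assay on SEM cells (Homo sapiens) for antiproliferative activity, with a stated time of 72 h (a lower number here means that less compound is needed, a higher number that more compound is needed for the effect), compound 1 gives only a limit, > 6350 nM. Compound 2 likewise gives only a limit, > 6350 nM. The step that the two limits leave unreadable from compound 1 to compound 2 stays unreadable since both values sit at the limit of > 6350 nM in this assay, at which 2 of the 2 values shown sit. Compound 2 therefore stands at the limit, with no number beneath it. Compound 3 `COC(=O)c1cc(=O)c2cc(NC(=O)Nc3ccc(F)c(Cl)c3)ccc2[nH]1` differs from compound 2 by fluoro in place of chloro on an aromatic carbon. Among the measured compounds shown here, the only measured step bears on this change and shows nothing readable, so no step beyond the scatter is expected in either direction. Compound 3 is expected at 10000 nM, range 4000 nM to 30000 nM, most likely again only a limit. The expected step that the limit leaves unreadable from compound 2 to compound 3 is thus none readable.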

Compound 3, half-maximal effective concentration: > 6350 nM
Compound 3: no number, only a limit (the forecaster's own chance of this, stated with the estimate: 85%); the middle value lies beyond the limit too.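

No step can be read between compound 2 and compound 3; each gives only a limit: the limit of > 6350 nM in this assay, at which 3 of the 3 values shown sit.
Left open is whether fluoro in place of chloro changes anything in this assay at concentrations beyond that limit.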